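Ring-closing the alpha carbon of the acid side chain

The source may hold more compounds than are shown below. What is called first, only, known or untested is meant among the compounds shown, and "the series" means these compounds.

Compound 2 `O=C(O)Cc1nn(Cc2cn3cc(OCC4CC4)c(Cl)cc3n2)c2ccccc2c1=O` carries the lowest of the two numbers recorded in a functional assay on CHO cells for antagonist activity at sphingosine 1-phosphate receptor 2 (Homo sapiens), read by GTPgammaS binding (on this read-out lower numbers stand for stronger inhibition and higher numbers for weaker inhibition), giving 30 nM; compound 1 `C[C@@H](C(=O)O)c1nn(Cc2cn3cc(OCC4CC4)c(Cl)cc3n2)c2ccccc2c1=O` gives 253 nM. Among the compounds with values here, the one measured step, an 8.4-fold lower number from compound 1 to compound 2 (0.93 log units; beyond the scatter), accompanied the loss of a methyl on the chain carbon bearing the acid. Compound 3 `O=C(O)C1(c2nn(Cc3cn4cc(OCC5CC5)c(Cl)cc4n3)c3ccccc3c2=O)CC1` moves the other way: 1-carboxycyclopropyl in place of carboxymethyl on an aromatic carbon. As that carbon regains substitution, the step of an 8.4-fold lower number from compound 1 to compound 2 (0.93 log units; beyond the scatter) is expected to be partly reversed, and compound 3 is estimated to give a weaker number, a 5.0-fold higher number from compound 2 to compound 3 (0.70 log units; beyond the scatter), around 150 nM with a range of 40 nM to 600 nM.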

Compound 3, half-maximal inhibitory concentration: 82 nM
Beside the measured number, compound 3's estimate is 1.8-fold (0.26 log units) above it, and the stated range covers the measured number.
By their numbers in this assay, from the lowest: compound 2; then compound 3; then compound 1.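

In this assay, closing the chain carbon bearing the acid into a cyclopropane gives a mixed result: there is a 2.7-fold higher number from compound 2 to compound 3 (0.44 log units; beyond the scatter), yet also a 3.1-fold lower number from compound 1 to compound 3 (0.49 log units; beyond the scatter). Substitution at this carbon therefore does not act as a single penalty, since the ring-closed 1-carboxycyclopropyl of compound 3 places it between the unsubstituted carboxymethyl of compound 2 and the 1-carboxyethyl of compound 1. Nothing available explains why the ring and the methyl differ. Open, on these data alone, is whether a 1-carboxycyclobutyl group or an open 2-carboxypropan-2-yl group would track compound 3 or compound 1.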